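This account rests on a few compounds, and the source may have more. Where it says the series, first, only, none or still open, it means among the compounds named here.

Working notes on the series. The shared core of compound 1 `CC(C)(C)OC(=O)N1CCC(O[C@H]2CC[C@H](Oc3cnc(S(C)(=O)=O)cn3)CC2)CC1` carries a methylsulfonyl on the aromatic ring; in a functional assay on isolated protein for agonist activity at Glucose-dependent insulinotropic receptor (Homo sapiens), read by HTRF and cAMP accumulation (on this read-out higher numbers stand for an effect only at larger amounts of compound and lower numbers for an effect already at smaller amounts), compound 1 gives 5.9 nM. Compound 2 `CC(C)(C)OC(=O)N1CCC(O[C@H]2CC[C@H](Oc3cnc(C#N)cn3)CC2)CC1` has cyano in place of methylsulfonyl on an aromatic carbon and in this assay compound 2 gives 8.3 nM. The step of a 1.4-fold higher number from compound 1 to compound 2 (0.15 log units; within the scatter) is the only one measured so far. On the two numbers at hand compound 2 shows the higher one, but its gap to compound 1 is inside the usual spread, so no order between the two can be claimed.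

Compound 3 `CC(C)(C)OC(=O)N1CCC(O[C@H]2CC[C@H](Oc3ccc(S(C)(=O)=O)nn3)CC2)CC1` differs from compound 2 in one place: 6-(methylsulfonyl)pyridazin-3-yl in place of 5-cyanopyrazin-2-yl on an oxygen on a saturated carbon. For the measured compounds named here, the single measured step, a 1.4-fold higher number from compound 1 to compound 2 (0.15 log units; within the scatter), bears on the exchange of cyano for methylsulfonyl and was small; the change of the aromatic ring itself, from the pyrazinyl of compounds 1 and 2 to the pyridazinyl of compound 3, has no measured counterpart here. The expectation for this assay is therefore a step that stays within the scatter, if anything towards a slightly lower number, as the step of a 1.4-fold lower number from compound 2 to compound 3 (0.14 log units; within the scatter) expresses. Compound 3 is accordingly estimated at 6 nM, with a range from 2.5 nM to 15 nM.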

Compound 3, half-maximal effective concentration: 651 nM
Beside the measured number, compound 3's estimate is 110-fold (2.04 log units) below it; measured number above the stated range.
By their numbers in this assay, from the lowest: compounds 1 and 2 (each within the scatter of the next); then compound 3.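

With the methylsulfonyl held constant, the step of a 110-fold higher number from compound 1 to compound 3 (2.04 log units; beyond the scatter) in this assay isolates the aromatic ring on the oxygen on a saturated carbon, and it shows that one six-membered aromatic ring with 2 hetero atoms cannot stand in for another at this place without a large change in the read-out. The step of a 78-fold higher number from compound 2 to compound 3 (1.89 log units; beyond the scatter) is also large, whereas the exchange of the substituent on the pyrazinyl ring, a 1.4-fold higher number from compound 1 to compound 2 (0.15 log units; within the scatter), stays within the scatter, so among these three compounds the identity of the ring counts for far more than the choice between cyano and methylsulfonyl. No measurement at hand speaks to why the pyridazinyl ring carries this penalty.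

From the compounds shown here alone, it remains open whether the large step belongs to the pyridazinyl ring as such or to its combination with methylsulfonyl, a question that a cyano on the pyridazinyl ring would address. Equally open, going by these compounds, is whether an amine or a carboxamide in place of methylsulfonyl on the pyridazinyl ring would change the read-out at all.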